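A few compounds are considered here, and "the series" means these few. Any claim that something is new, unique, unknown or untested is made for them only; others in the source may bear on it.

Measured in a functional assay on HT-29 cells (Homo sapiens) for antiproliferative activity, read by MTT assay, with a stated time of 72 h; a higher number here means a weaker inhibitor, a lower number a stronger inhibitor:

- Compound 1 `Nc1nc(N)c2cc(CSC(=S)N3CCN(c4ccc(Cl)cc4)CC3)ccc2n1`: 7480 nM
- Compound 2 `Nc1nc(N)c2cc(CSC(=S)N3CCN(c4ccccn4)CC3)ccc2n1`: 6200 nM

A lower number here marks a stronger inhibitor, so both compounds can be read directly against each other. Within the data shown here, compound 2 stands at 6200 nM, and only one other compound has been measured so far. The gap between the two is small: a 1.2-fold lower number from compound 1 to compound 2 (0.08 log units; within the scatter). On these numbers, the two cannot be told apart.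

The next compound is compound 3 `Nc1nc(N)c2cc(CSC(=S)N3CCN(c4ncccn4)CC3)ccc2n1`. It keeps everything else and carries pyrimidin-2-yl in place of pyridin-2-yl on an amine nitrogen in a ring.

Among the measured compounds shown here, only one measured step bears on this change, the swap at the same place of 4-chlorophenyl for pyridin-2-yl. That swap, a 1.2-fold lower number from compound 1 to compound 2 (0.08 log units; within the scatter), stayed within the scatter in this assay. A single step is thin evidence, but it gives no reason to expect a large shift here, in either direction. The expected change is a 1.0-fold lower number from compound 2 to compound 3 (0.01 log units; within the scatter), which means no step beyond the scatter. For compound 3 the estimated value is 6000 nM, with an expected range from 2500 nM to 14000 nM.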

Compound 3, half-maximal inhibitory concentration: 4720 nM
Beside the measured number, compound 3's estimate is 1.3-fold (0.10 log units) above it, within the range that was stated.
By their numbers in this assay, from the lowest: compounds 3, 2 and 1 (each within the scatter of the next).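

Replacing pyridin-2-yl with pyrimidin-2-yl adds a second hetero atom to the aromatic ring and raises the hydrogen-bond acceptor count of the group from 1 to 2, yet in this assay the result stays within the scatter (a 1.3-fold lower number from compound 2 to compound 3 (0.12 log units; within the scatter)). The comparison between pyrimidin-2-yl and 4-chlorophenyl on the same amine nitrogen in a ring also stays within the scatter (a 1.6-fold lower number from compound 1 to compound 3 (0.20 log units; within the scatter)), so compounds 1, 2 and 3 cannot be told apart, even though this position now carries three different aromatic groups. No measurement at hand accounts for these readings, so the data show this similarity without explaining it.

Every group shown at this position is a six-membered aromatic ring joined directly to the amine nitrogen, so it remains open whether a benzyl group, a cyclohexyl group or a simple methyl group would give a step beyond the scatter. From the compounds shown here alone, it is equally open whether an aromatic ring bearing an amine or a carboxylic acid would separate itself from these three compounds.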